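Exchanging the aryl group on a ring nitrogen

A few compounds are considered here, and "the series" means these few. Any claim that something is new, unique, unknown or untested is made for them only; others in the source may bear on it.

Compound 2 `Cc1ccc(N2C(=O)[C@H]3[C@H](ON4[C@@H]3C(=O)N(C)[C@@]43C[C@H](C)CC[C@H]3C(C)C)C2=O)c(C)c1` in a functional assay, with a stated time of 20 min, tested at 2.5 mg/mL (on this read-out lower numbers stand for a weaker effect and higher numbers for a stronger effect at the one concentration tested), gives 77.1%. For the measured compounds named here, its only measured neighbour is compound 1 `CC(C)[C@@H]1CC[C@@H](C)C[C@@]12N(C)C(=O)[C@@H]1[C@H]3C(=O)N(c4ccccc4)C(=O)[C@H]3ON12`, which in this assay gives 76.2%, and the two numbers lie within the usual scatter of each other, so they cannot be told apart. Going by the values given here, the one step measured so far, a number 0.9 percentage points higher from compound 1 to compound 2 (within the scatter), is the step between these two. Compound 3 `CC(C)[C@@H]1CC[C@@H](C)C[C@@]12N(C)C(=O)[C@@H]1[C@H]3C(=O)N(c4ccc5ccccc5c4)C(=O)[C@H]3ON12` differs from compound 2 in one place: naphthalen-2-yl in place of 2,4-dimethylphenyl on an amide-type nitrogen in a ring. This is the same kind of change as the measured one, an exchange of the aromatic group on the amide-type nitrogen in a ring, and that earlier exchange moved the read-out only within the scatter. On this basis no step beyond the scatter is expected in this assay in either direction, and the expected step is a number 2.1 percentage points lower from compound 2 to compound 3 (within the scatter). Compound 3 is therefore estimated to give 75% in this assay, with a range from 60% to 88%.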

Compound 3, a percentage reported as activity, at one concentration (the size of the read-out at that concentration, not a potency): 39.6%
Estimate against measurement, compound 3: 35.4 percentage points above; the measured number lies below the stated range.
By their numbers in this assay, from the lowest: compound 3; then compounds 1 and 2 (each within the scatter of the next).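

This position is not indifferent to the aryl group after all: in this assay, naphthalen-2-yl in place of 2,4-dimethylphenyl gives a number 37.5 percentage points lower from compound 2 to compound 3 (beyond the scatter), and in place of phenyl it gives a number 36.6 percentage points lower from compound 1 to compound 3 (beyond the scatter). Compound 1 and compound 2 cannot be told apart, so a group with one six-membered aromatic ring, with or without the two methyl groups, reads alike here, and only the group with two such rings stands apart. Nothing available explains this drop.

Three compounds cannot show whether the second aromatic ring itself matters or some other feature of naphthalen-2-yl. As far as these compounds go, how the read-out responds to a non-aromatic group such as cyclohexyl, or to a phenyl carrying an amine or a carboxylic acid, also remains open.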